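Cyclobutyl replacing 4-methoxycyclohexyl: expected half-life

This account rests on a few compounds, and the source may have more. Where it says the series, first, only, none or still open, it means among the compounds named here.

Compound 1 `Nc1ncnc2c1c(Oc1cc(Cl)ccn1)nn2C1CCC1`: 0.333 h
Compound 2 `CO[C@H]1CC[C@H](n2nc(Oc3cc(C(F)(F)F)ccn3)c3c(N)ncnc32)CC1`: > 2.41 h

In an ADME assay on microsomes from liver (Homo sapiens) for metabolic stability, read by LC-MS, using NADPH, with a stated time of 10 min, tested at 10 uM (a higher number here means that the compound lasts longer, a lower number that the compound disappears faster), compound 2 reads > 2.41 h, which is a limit and not a number. Compound 2 therefore stands at the limit of > 2.41 h in this assay, at which 1 of the 2 values shown sits.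

Compound 3 `Nc1ncnc2c1c(Oc1cc(C(F)(F)F)ccn1)nn2C1CCC1` follows from compound 2 with cyclobutyl in place of 4-methoxycyclohexyl on an aromatic nitrogen. Within the data shown here, no measured pair isolates this change, so the expectation rests on a single neighbour. Compound 1 also carries cyclobutyl on that nitrogen and gives 0.333 h. On that basis, a fall in half-life well beyond the usual scatter is expected in this assay, estimated as an at least 5.3-fold lower number from compound 2 to compound 3 (0.72 log units; beyond the scatter). The expected value for compound 3 is 0.45 h, with an estimated range of 0.2 h to 1.1 h.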

Compound 3, half-life: 1.02 h
Beside the measured number, compound 3's estimate is 2.3-fold (0.36 log units) below it; the range from low to high includes it.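

On the aromatic nitrogen, with trifluoromethyl held constant, cyclobutyl in place of 4-methoxycyclohexyl now has a direct reading in this assay, with an at least 2.3-fold lower number from compound 2 to compound 3 (0.37 log units; beyond the scatter). Going by these compounds, the true size of this step stays unknown, and the reading for compound 2 is a limit and not a number: the limit of > 2.41 h in this assay, at which 1 of the 3 values shown sits. With cyclobutyl held on that nitrogen, trifluoromethyl in place of chloro on an aromatic carbon also moves the half-life, with a 3.1-fold higher number from compound 1 to compound 3 (0.49 log units; beyond the scatter), so both places in the series bear on this read-out.

The compounds shown do not separate the contribution of the methoxy group from that of the six-membered ring, which an unsubstituted cyclohexyl or a hydroxycyclohexyl on the same nitrogen would address. Among these compounds, it also remains open whether the two changes add up, as 4-methoxycyclohexyl has been seen only with trifluoromethyl.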